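Sulfonyl aryl replacement in the piperidinyl-piperidine sulfonamide series

The source may hold more compounds than are shown below. What is called first, only, known or untested is meant among the compounds shown, and "the series" means these compounds.

Measured so far in a functional assay on DLD-1 cells (Homo sapiens) for antiproliferative activity, read by CellTiter-Glo, with a stated time of 72 h; on this read-out lower numbers stand for stronger inhibition and higher numbers for weaker inhibition:
- compound 1 `CC1CCN(C2CCN(S(=O)(=O)c3ccc(F)cc3F)CC2)CC1` gives 102 nM
- compound 2 `Cc1ccc(-c2ccccc2S(=O)(=O)N2CCC(N3CCC(C)CC3)CC2)cc1` gives 366 nM
- compound 3 `COc1ccc(-c2ccccc2S(=O)(=O)N2CCC(N3CCC(C)CC3)CC2)cc1` gives 1000 nM

Compound 1 has the lowest number of the three, and its gaps to compound 2 and to compound 3 both lie beyond the scatter. Among the measured pairs only one single-point step exists: a 2.7-fold higher number from compound 2 to compound 3 (0.44 log units; beyond the scatter). That step concerns a substituent on the distal aromatic ring of a biaryl sulfonyl group and does not touch the sulfonyl aryl itself.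

Compound 4 `CC1CCN(C2CCN(S(=O)(=O)c3cccc(N)c3)CC2)CC1` differs from compound 1 as follows: 3-aminophenyl in place of 2,4-difluorophenyl on a sulfonyl sulfur. For the measured compounds named here, no measured step bears directly on this exchange; the series holds no other change at the sulfonyl aryl. The expectation therefore rests on compound 1 alone, with wide uncertainty, and a small loss is taken as the central case: the step is estimated as a 2.2-fold higher number from compound 1 to compound 4 (0.33 log units; beyond the scatter). Compound 4 is expected to give about 220 nM in this assay, within a range of 70 nM to 700 nM.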

Compound 4, half-maximal inhibitory concentration: 3400 nM
Beside the measured number, compound 4's estimate is 15-fold (1.19 log units) below it, and the stated range ends below it.
By their numbers in this assay, from the lowest: compound 1; then compound 2; then compound 3; then compound 4.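

In this assay the sulfonyl aryl proves a sensitive position: with the rest of the molecule unchanged, 3-aminophenyl in place of 2,4-difluorophenyl on the sulfonyl sulfur gives a 33-fold higher number from compound 1 to compound 4 (1.52 log units; beyond the scatter), a large loss. For the compounds shown here, the earlier single-point step concerned only the distal ring of a biaryl sulfonyl group, so this is the first direct reading of a change at the aryl on sulfur. No supporting data are available to explain the size of this step.

Since the exchange removes both fluorines and adds the amine in one move, the shares of the two changes cannot be separated. Going by these compounds, whether an unsubstituted phenyl, a hydroxyl group or an acetamide on this aryl would stay nearer to compound 1 remains open.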